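Adding a Methoxy Group to Compound 1

This account rests on a few compounds, and the source may have more. Where it says the series, first, only, none or still open, it means among the compounds named here.

Compound 1 (`CC(C)NC(=N)c1ccc(-c2cc3cc(C(=N)NC(C)C)ccc3o2)cc1`) was tested in an ADME assay on L6 cells (Rattus norvegicus) for cytotoxicity; a lower number here means a stronger inhibitor, a higher number a weaker inhibitor. In this assay compound 1 gives > 198000 nM, which is a limit of the assay and not a number. Its true position is therefore unknown, and the data hold only (the limit of > 198000 nM in this assay, at which 1 of the 2 values shown sits). For the measured compounds named here, the one numerical reading comes from compound 2 (`N=C(N)c1cccc(-c2cc3ccc(C(=N)N)cc3o2)c1`), which gives 131000 nM.

Compound 3 (`COc1cc(C(=N)NC(C)C)cc2cc(-c3ccc(C(=N)NC(C)C)cc3)oc12`) has not yet been measured. It carries methoxy in place of hydrogen on an aromatic carbon, part of a fused or bridged system of two rings, and otherwise keeps the core of compound 1: methoxy in place of hydrogen on an aromatic carbon.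

Going by the values given here, no measured pair shows what such a change does in this assay, so any expectation is loose. A modest step toward a lower number is expected, and its estimated size is an at least 1.5-fold lower number from compound 1 to compound 3 (0.18 log units; that floor lies within the scatter). Among the compounds with values here, that expectation leans on compound 2 at 131000 nM, the only reading that is a number. Compound 3 may well reach the limit too. Compound 3 is estimated at 130000 nM, with an expected range from 45000 nM to 260000 nM.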

Compound 3, half-maximal inhibitory concentration: > 190000 nM
Compound 3 gave a limit, no number (the forecaster's own chance of this, stated with the estimate: 40%); at least 1.4-fold (0.16 log units) between middle value and limit.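

In this assay compound 3 gives > 190000 nM, which is a limit of the assay and not a number. Compound 1 also stands at a limit, so no step can be read between compound 1 and compound 3. The compounds shown leave open whether methoxy in place of hydrogen on an aromatic carbon changes the value at all.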